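The source may report more compounds than this note shows. Statements on the series, on what has been measured and on what is new or still open speak of the compounds shown alone.

The measured compounds:
Compound 1, `Cc1ccc(-c2nnc(-c3ccc(CN4CCN(C)CC4)c(C(F)(F)F)c3)o2)cc1Nc1nccc(-c2cccnc2)n1`, gives 580 nM in a functional assay on KG-1a cells (Homo sapiens) for inhibition, read by MTT assay, with a stated time of 72 h; on this read-out higher numbers stand for weaker inhibition and lower numbers for stronger inhibition.
Compound 2, `Cc1ccc(-c2nnc(-c3ccc(C)c(C(F)(F)F)c3)o2)cc1Nc1nccc(-c2cccnc2)n1`, gives only a limit of the assay, > 30000 nM, in this assay.
Compound 3, `Cc1ccc(-c2nnc(-c3ccc(F)c(C(F)(F)F)c3)o2)cc1Nc1nccc(-c2cccnc2)n1`, likewise gives only a limit of the assay, > 30000 nM, in this assay.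

Compound 3 therefore sits at the limit of > 30000 nM in this assay, at which 2 of the 3 values shown sit; its true number is not known, only that it lies beyond what the assay reports. Compound 4, `Cc1ccc(-c2nnc(-c3ccc(CN4CCN(CCN)CC4)c(C(F)(F)F)c3)o2)cc1Nc1nccc(-c2cccnc2)n1`, differs from compound 3 by (4-(2-aminoethyl)piperazin-1-yl)methyl in place of fluoro on an aromatic carbon.

Among the measured compounds shown here, two measured steps bear on this change. In this assay the step of an at least 51-fold higher number from compound 1 to compound 3 (1.71 log units; beyond the scatter) shows that taking away the (4-methylpiperazin-1-yl)methyl group and putting fluoro in its place raises the number by a large amount; the step of an at least 51-fold higher number from compound 1 to compound 2 (1.71 log units; beyond the scatter) shows the same when hydrogen replaces the 4-methylpiperazin-1-yl part. For the measured compounds named here, compound 4 goes the other way round: it restores a group of the same kind, differing from the one in compound 1 only in the chain carried on its ring. A large downward step an at least 50-fold lower number from compound 3 to compound 4 (1.69 log units; beyond the scatter) is therefore expected, bringing compound 4 close to where compound 1 stands.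

Compound 4 is expected to give about 600 nM in this assay, within a range from 150 nM to 3000 nM.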

Compound 4, half-maximal inhibitory concentration: 480 nM
Compound 4: middle estimate off by 1.3-fold (0.10 log units), on the high side, within the range that was stated.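

In this assay, putting (4-(2-aminoethyl)piperazin-1-yl)methyl on this aromatic carbon in place of fluoro gives an at least 62-fold lower number from compound 3 to compound 4 (1.79 log units; beyond the scatter), and setting 4-(2-aminoethyl)piperazin-1-yl on the saturated chain carbon in place of hydrogen gives an at least 62-fold lower number from compound 2 to compound 4 (1.79 log units; beyond the scatter). Compound 1 alone could not show whether this large gain depended on its particular 4-methylpiperazin-1-yl group, but a second piperazine with a different chain now shows the same large gain. The chain carried on the piperazine ring can therefore change without a readable effect, since adding aminomethyl gives a 1.2-fold lower number from compound 1 to compound 4 (0.08 log units; within the scatter), and compound 1 and compound 4 cannot be told apart in this assay.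

As far as these compounds go, the true size of the two large steps stays open, because each starts from a compound that reports only a limit of the assay: the limit of > 30000 nM in this assay, at which 2 of the 4 values shown sit. It also stays open whether the piperazine ring itself is needed, or whether a morpholine ring or a simple dimethylamino group on the same carbon would do as well, and how a longer chain or a carboxylic acid on the piperazine ring would fare.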